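The source may hold more compounds than are shown below. What is called first, only, known or untested is meant among the compounds shown, and "the series" means these compounds.

Working notes on the series. Compound 1 `CNc1nc(NCCCN(C)C)c2sc(-c3cccc(C#N)c3)cc2n1` has been measured in a physicochemical assay for solubility, at pH 2; a higher number here means a more soluble compound, a lower number a less soluble compound. For compound 1 the result is only a limit of the assay, > 100 ug/mL, and not a number. Compound 2 `CNc1nc(NCCCN(C)C)c2sc(-c3ccoc3)cc2n1` gives 221 ug/mL in this assay, and compound 3 `CNc1nc(NCCCN(C)C)c2sc(-c3cncnc3)cc2n1` gives 214 ug/mL. Between these two the step of a 1.0-fold lower number from compound 2 to compound 3 (0.01 log units; within the scatter) is within the scatter, so no order can be set between them. The steps from compound 1 are a step that the limit leaves unreadable from compound 1 to compound 2 and a step that the limit leaves unreadable from compound 1 to compound 3; the evidence here is the limit of > 100 ug/mL in this assay, at which 1 of the 3 values shown sits, which leaves their size and direction unknown.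

Compound 4 `CNc1nc(NCCCN(C)C)c2sc(-c3cccc(C(F)(F)F)c3)cc2n1` is not yet measured. It differs from compound 1 by trifluoromethyl in place of cyano on an aromatic carbon. None of the three measured steps changes this group: each of them exchanges the whole ring, and the two that start from compound 1 cannot be read against (the limit of > 100 ug/mL in this assay, at which 1 of the 3 values shown sits). Going by the values given here, no measured step therefore bears directly on the change, and no size or direction of step in this assay can be taken from the data; the numbers of compound 2 and compound 3 only show where two other members sit.

For compound 4 a value of 60 ug/mL is estimated in this assay, with a range from 10 ug/mL to 250 ug/mL. This estimate means an at least 1.6-fold lower number from compound 1 to compound 4 (0.22 log units; that floor lies within the scatter), a step that is expected to stay unreadable against the limit of compound 1.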

Compound 4, solubility: 180 ug/mL
Compound 4: the middle estimate sits 3.0-fold (0.48 log units) below what was measured; the range from low to high includes it.
By their numbers in this assay, from the lowest: compounds 4, 3 and 2 (each within the scatter of the next).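

The step from compound 1 to compound 4 cannot be read in this assay, because the result for compound 1 is a limit of the assay and not a number: the limit of > 100 ug/mL in this assay, at which 1 of the 4 values shown sits.

The compounds shown therefore leave open both the direction and the size of the change in this assay when trifluoromethyl stands in place of cyano on an aromatic carbon.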